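A few compounds are considered here, and "the series" means these few. Any claim that something is new, unique, unknown or untested is made for them only; others in the source may bear on it.

Measured so far in an ADME assay on L6 cells (Rattus norvegicus) for cytotoxicity, read by resazurin assay, with a stated time of 70 h; on this read-out higher numbers stand for an effect only at larger amounts of compound and lower numbers for an effect already at smaller amounts:

- Compound 1 `CC(=O)Nc1cnc2[nH]c(=O)n([C@H]3CC[C@H](C(C)(C)C)CC3)c(=O)c2c1` gives 67000 nM
- Compound 2 `CC(=O)Nc1cnc2[nH]c(=O)n([C@H]3CC[C@@H](C(C)(C)C)CC3)c(=O)c2c1` gives 15000 nM
- Compound 3 `CC(C)(C)[C@H]1CC[C@H](n2c(=O)[nH]c3ncc(N)cc3c2=O)CC1` gives 63000 nM

Compound 3 sits with compound 1 at the upper end of these numbers, and a 1.1-fold lower number from compound 1 to compound 3 (0.03 log units; within the scatter) places the two within the scatter. Compound 2 shows the lower value of 15000 nM and stands apart from both.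

The next compound is compound 4 `CC(C)(C)[C@H]1CC[C@@H](n2c(=O)[nH]c3ncc(N)cc3c2=O)CC1`, and the change is the two compounds have the same atoms and bonds and differ only in configuration as drawn: 2 of 2 stereo elements differ (all stereocentres are inverted: mirror images); a stereocentre at a saturated ring carbon is drawn r in compound 3 and s in compound 4; a stereocentre at a saturated ring carbon is drawn r in compound 3 and s in compound 4 (all stereocentres inverted, mirror images as drawn). Within the data shown here, the closest precedent is a 4.5-fold lower number from compound 1 to compound 2 (0.65 log units; beyond the scatter), a modest step that goes with the fact that compounds 1 and 2 differ only in the configuration as drawn. That is a single pair carrying acetyl, while compound 3 carries hydrogen in its place. Even so, a 1.1-fold lower number from compound 1 to compound 3 (0.03 log units; within the scatter) shows that this exchange left the number within the scatter, so the same inversion is expected to act much alike here.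

The expected result in this assay is a 4.2-fold lower number from compound 3 to compound 4 (0.62 log units; beyond the scatter), a lower number of similar size.

For compound 4 the estimate is 15000 nM, with an expected range from 7000 nM to 40000 nM.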

Compound 4, half-maximal effective concentration: 44000 nM
Compound 4: middle estimate off by 2.9-fold (0.47 log units), on the low side; measured number outside the range, above it.
By their numbers in this assay, from the lowest: compound 2; then compounds 4, 3 and 1 (each within the scatter of the next).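

In this assay the inversion of both ring stereocentres does not give the same result with hydrogen on the aromatic nitrogen as with acetyl there: a 1.4-fold lower number from compound 3 to compound 4 (0.16 log units; within the scatter) stays within the scatter, against a 4.5-fold lower number from compound 1 to compound 2 (0.65 log units; beyond the scatter). Hydrogen in place of acetyl, which left the number within the scatter in the first configuration, now gives a 2.9-fold higher number from compound 2 to compound 4 (0.47 log units; beyond the scatter), so compound 2 alone stands apart. Within these four compounds the exchange therefore reads differently on the two configurations: the same change on two cores in this assay, a 1.1-fold lower number (0.03 log units; within the scatter) from compound 1 to compound 3 and a 2.9-fold higher number (0.47 log units; beyond the scatter) from compound 2 to compound 4, 3.1-fold (0.49 log units) apart, beyond the scatter of two such steps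

From the compounds shown here alone, whether the lower number of compound 2 is specific to acetyl or also appears with a propionyl or methanesulfonyl group on that nitrogen remains open. Also open, going by these compounds, is whether the configuration still matters when a cyclopropyl or a methyl group stands in place of the tert-butyl group.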